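Series notes: acetyl in place of methyl, awaiting measurement

The source may report more compounds than this note shows. Statements on the series, on what has been measured and on what is new or still open speak of the compounds shown alone.

Compound 1 `Cc1ccc(Nc2ccc3c(c2)C(=O)N(C2CCC(=O)NC2=O)C3=O)cc1`: 5%
Compound 2 `Cc1ccc(Nc2cccc3c2C(=O)N(C2CCC(=O)NC2=O)C3=O)cc1`: 9%

In an assay on FRT-Jurkat cells for inhibition of nuclear factor NF-kappa-B complex (Homo sapiens), read by flow cytometry, with a stated time of 24 h, tested at 10 uM (on this read-out higher numbers stand for more inhibition at the one concentration tested (going by the name of the read-out) and lower numbers for less inhibition), compound 1 gives 5%, and compound 2 gives 9%. The two numbers lie within the scatter of each other, so compound 1 and compound 2 cannot be told apart here; both sit near the bottom of the scale.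

Compound 3 `CC(=O)c1ccc(Nc2ccc3c(c2)C(=O)N(C2CCC(=O)NC2=O)C3=O)cc1` is not yet measured. It differs from compound 1 by acetyl in place of methyl on an aromatic carbon. Within the data shown here, no step between measured compounds informs this change, so no step beyond the scatter is expected, the estimated step being a number 3 percentage points higher from compound 1 to compound 3 (within the scatter). For compound 3 the expected value in this assay is 8%, with a range from -5% to 25%.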

Compound 3, a percentage reported as inhibition, at one concentration (the size of the read-out at that concentration, not a potency): -2%
For compound 3 the middle estimate is 10 percentage points above the measured one; the range from low to high includes it.
By their numbers in this assay, from the lowest: compounds 3, 1 and 2 (each within the scatter of the next, the first and the last beyond it).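

In this assay, acetyl in place of methyl on this aromatic carbon, para to a large group, gives a step that reads a number 7 percentage points lower from compound 1 to compound 3 (within the scatter), so at this position the change cannot be told apart from no change. The added carbonyl thus brings no gain in inhibition that can be read at this concentration. No measurement at hand bears on the reason for this result.

Open, on these data alone, is whether an amine, a carboxylic acid or a longer chain on this aromatic carbon would stand beyond the scatter of compound 1. Also open, as far as these compounds go, is whether acetyl reads the same on the core of compound 2.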